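The source may report more compounds than this note shows. Statements on the series, on what has been measured and on what is new or still open speak of the compounds shown alone.

In a functional assay on the whole organism (strain Kunming) for inhibition, with Mus musculus as the target, in the writhing test, at a dose of 40 mg/kg by the oral route (a higher number here means more inhibition at the dose given (going by the name of the read-out), a lower number less inhibition), compound 1 `CNC(=O)c1cc(-c2ccc(F)cc2F)ccc1OC(=O)c1ccccc1` gives 47.5% and compound 2 `Cc1ccccc1NC(=O)c1cc(-c2ccc(F)cc2F)ccc1OC(=O)c1ccccc1` gives 20.8%; the step of a number 26.7 percentage points lower from compound 1 to compound 2 (beyond the scatter) shows the change. Compound 2 thus stands lowest of the two measured numbers. Compound 3 `CCN(CC)C(=O)c1cc(-c2ccc(F)cc2F)ccc1OC(=O)c1ccccc1` differs from compound 2 by diethylamino in place of (2-methylphenyl)amino on a carbonyl carbon. Going by the values given here, only one measured step bears on this: there a small alkyl on the amide-type nitrogen gave the higher number, so a return toward an alkyl substitution is expected to raise inhibition, though the tertiary amide has no precedent. Compound 3 is estimated at 35%, between 15% and 55%, a step of a number 14.2 percentage points higher from compound 2 to compound 3 (beyond the scatter).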

Compound 3, a percentage reported as inhibition, in the whole organism at one dose (the size of the read-out at that dose, not a potency): 0%
Compound 3: middle estimate off by 35 percentage points, on the high side, outside the stated range (below it).
By their numbers in this assay, from the lowest: compound 3; then compound 2; then compound 1.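

In this assay, the change to diethylamino gives a number 20.8 percentage points lower from compound 2 to compound 3 (beyond the scatter), and the comparison with methylamino gives a number 47.5 percentage points lower from compound 1 to compound 3 (beyond the scatter). An alkyl group on this nitrogen therefore does not by itself keep inhibition, and compound 3, the only one of the three without the amide hydrogen, gives the lowest number. Nothing available here bears on why this substitution behaves so differently.

From the compounds shown here alone, it remains open whether the drop follows the loss of the amide hydrogen or the change in the alkyl groups. Ethylamino and dimethylamino on the same carbonyl carbon would separate these two readings.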